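The compounds below may be only part of what the source reports. "The series", "measured", "known", "first", "only" and "open" are said of these compounds alone.

Within the data shown here, compound 3 `CC(=O)OC/C(=C\c1ccc(F)cc1)C(=O)c1ccccc1` holds the second highest of the three numbers so far in a functional assay on HeLa cells (Homo sapiens) for inhibition, read by sulforhodamine B assay, with a stated time of 48 h (on this read-out lower numbers stand for stronger inhibition of growth and higher numbers for weaker inhibition of growth), where compound 3 gives 25000 nM; compound 2 `CC(=O)OC/C(=C\c1ccccc1)C(=O)c1ccccc1` gives 20000 nM and compound 1 `CCC(/C=C(\COC(C)=O)C(=O)c1ccccc1)CC` gives 50000 nM. The step of a 1.3-fold higher number from compound 2 to compound 3 (0.10 log units; within the scatter) lies within the scatter, whereas a 2.5-fold lower number from compound 1 to compound 2 (0.40 log units; beyond the scatter) and a 2.0-fold lower number from compound 1 to compound 3 (0.30 log units; within the scatter) set the two aryl compounds apart from the alkyl one. Compound 4 `CC(=O)OC/C(=C\c1ccccc1Br)C(=O)c1ccccc1` carries 2-bromophenyl in place of 4-fluorophenyl on a double-bonded chain carbon bound to a double-bonded chain carbon. Among the measured compounds shown here, the only measured step that bears on a change within the aryl group is a 1.3-fold higher number from compound 2 to compound 3 (0.10 log units; within the scatter), which stayed within the scatter; no measured step covers a bromine or a 2-substituted ring. In this assay a step within the scatter is therefore expected, no change at the digits printed from compound 3 to compound 4 (within the scatter). Compound 4 is estimated at 25000 nM, with a range of 10000 nM to 60000 nM.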

Compound 4, concentration for 50% growth inhibition: 20000 nM
Compound 4: the middle estimate sits 1.3-fold (0.10 log units) above what was measured; the range from low to high includes it.
By their numbers in this assay, from the lowest: compounds 2, 4, 3 and 1 (each within the scatter of the next, the first and the last beyond it).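

In this assay, bromo in place of hydrogen gives no change at the digits printed from compound 2 to compound 4 (within the scatter), and 2-bromophenyl in place of 4-fluorophenyl gives a 1.3-fold lower number from compound 3 to compound 4 (0.10 log units; within the scatter), so this place on a double-bonded chain carbon accepts a 2-bromophenyl group with no step beyond the scatter. Against pentan-3-yl, 2-bromophenyl gives a 2.5-fold lower number from compound 1 to compound 4 (0.40 log units; beyond the scatter), which matches the step seen with phenyl. Nothing available explains these numbers. On these data alone, whether an amine or a carboxylic acid on the aryl group would move the number beyond the scatter remains open.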